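Lengthening the hydroxyalkyl amide chain on a shared core

This account rests on a few compounds, and the source may have more. Where it says the series, first, only, none or still open, it means among the compounds named here.

Of the compounds shown here, two have been measured so far in an assay on HEK293 cells for displacement of a labelled ligand from adenosine receptor A2b (Homo sapiens), read by scintillation counting, with a stated time of 30 min, tested at 10 uM; a higher number here means more inhibition at the concentration tested (going by the name of the read-out), a lower number less inhibition. Compound 1 `N=c1oc2ccc(Br)cc2cc1C(=O)NCCO` gives 15%, and compound 2 `COc1cccc2cc(C(=O)Nc3c(C#N)ncn3-c3ccc(F)cc3)c(=N)oc12` gives 30%. The two structures differ in more than one place, so only their values can be set side by side: compound 1 stands lowest of the two numbers, and its nearest neighbour, compound 2, lies higher by a difference beyond the usual scatter.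

Compound 3 `N=c1oc2ccc(Br)cc2cc1C(=O)NCCCO` has not yet been measured. It differs from compound 1 in one place: hydroxymethyl in place of hydroxy on a saturated chain carbon, two bonds along the chain from an amide-type nitrogen. The shared core and the amide itself are unchanged.

Among the compounds with values here, no measured pair shows what a change of this kind does in this assay. Within the data shown here, because compound 1 sits low at 15%, there is little room for a large drop, and no measured step suggests a rise. The step of a number 1 percentage points higher from compound 1 to compound 3 (within the scatter) is expected to stay within the scatter, in no clear direction. Compound 3 is therefore estimated at 16%, with a range from 0% to 35%.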

Compound 3, a percentage reported as inhibition, at one concentration (the size of the read-out at that concentration, not a potency): 25%
The estimate for compound 3 lay 9 percentage points below the measured number, within the range that was stated.
By their numbers in this assay, from the lowest: compounds 1, 3 and 2 (each within the scatter of the next, the first and the last beyond it).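

In this assay, the change of hydroxy to hydroxymethyl on a saturated chain carbon, two bonds along the chain from an amide-type nitrogen, now has a measured step of its own: a number 10 percentage points higher from compound 1 to compound 3 (within the scatter). Within the data shown here, this is the first reading at this position on an otherwise unchanged core, and it shows that going from the 2-hydroxyethyl chain to the 3-hydroxypropyl chain does not separate the two compounds in this read-out at the concentration tested. A single pair gives no trend along the chain, and no information bears on why the two numbers fall where they do.

What the compounds shown leave open is whether a 4-hydroxybutyl chain, or a plain propyl chain without the hydroxy, would give a number that can be told apart from that of compound 1 beyond the scatter. As far as these compounds go, it is also open whether an amine or a carboxylic acid at the chain end, in place of hydroxy, would move the number at this position on the shared core.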